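A few compounds are considered here, and "the series" means these few. Any claim that something is new, unique, unknown or untested is made for them only; others in the source may bear on it.

Compound 1 `CC(C)(N)CN(C(=O)[C@@H]1C[C@H]1c1ccccc1)c1ccc(-c2ccccc2)cc1`: 1.4 nM
Compound 2 `O=C([C@@H]1C[C@H]1c1ccccc1)N(CC1CCCNC1)c1ccc(-c2ccccc2)cc1`: 10 nM
Compound 3 `CC[C@H](C)[C@H](N)CN(C(=O)[C@@H]1C[C@H]1c1ccc(F)cc1)c1ccc(-c2ccccc2)cc1`: 600 nM

In a functional assay for agonist activity at G protein-coupled receptor 88 (Homo sapiens), read by HTRF and cAMP accumulation (on this read-out higher numbers stand for an effect only at larger amounts of compound and lower numbers for an effect already at smaller amounts), compound 3 gives 600 nM, the highest of the three numbers, with both other compounds beyond the scatter below it. Compound 4 `CC[C@H](C)[C@H](N)CN(C(=O)[C@@H]1C[C@H]1c1nc(C)c(C)s1)c1ccc(-c2ccccc2)cc1` differs from compound 3 in one place: 4,5-dimethyl-1,3-thiazol-2-yl in place of 4-fluorophenyl on a saturated ring carbon. Within the data shown here, only one step has been measured, a 7.1-fold higher number from compound 1 to compound 2 (0.85 log units; beyond the scatter), and it concerns the group on the saturated chain carbon bound to the amide-type nitrogen, not the group on the three-membered ring, so it does not bear on this change. Among the measured compounds shown here, with no comparable step available, the step from compound 3 is expected to be none beyond the scatter: no change at the digits printed from compound 3 to compound 4 (within the scatter). Compound 4 is therefore estimated at 600 nM, with a wide range from 100 nM to 3000 nM.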

Compound 4, half-maximal effective concentration: 3600 nM
Compound 4: the middle estimate sits 6.0-fold (0.78 log units) below what was measured; the whole stated range lies below it.
By their numbers in this assay, from the lowest: compound 1; then compound 2; then compound 3; then compound 4.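

In this assay the group on the saturated ring carbon of the three-membered ring proves to matter: 4,5-dimethyl-1,3-thiazol-2-yl in place of 4-fluorophenyl gives a 6.0-fold higher number from compound 3 to compound 4 (0.78 log units; beyond the scatter) and so a change beyond the scatter, even though both groups have the same count of heavy atoms. The earlier step concerned only the group on the saturated chain carbon. Nothing shown accounts for this new step.

Open, from the compounds shown here alone, is whether a pyridin-2-yl or a thiazol-2-yl without its two methyl groups would behave like either group here. Also open, going by these compounds, is whether this change would cost as much with the 1-amino-1-methylethyl group of compound 1.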